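The source may hold more compounds than are shown below. What is called first, only, known or untested is meant among the compounds shown, and "the series" means these compounds.

Measured in a functional assay on K562 cells (Homo sapiens) for inhibition, read by trypan blue exclusion, with a stated time of 72 h; on this read-out higher numbers stand for weaker inhibition and lower numbers for stronger inhibition:
- compound 1 `COc1ccc(Nc2ncc3cc(S(=O)(=O)c4ccc(Cl)cc4)c(=O)n(C)c3n2)cc1`: 15000 nM
- compound 2 `O=c1[nH]c2nc(Nc3ccc4[nH]ccc4c3)ncc2cc1S(=O)(=O)c1ccc(F)cc1F`: 15000 nM
- compound 3 `Cn1c(=O)c(S(=O)(=O)c2ccc(Cl)cc2)cc2cnc(Nc3cccc4[nH]ccc34)nc21`: 5000 nM

Compound 2, at 15000 nM, is level with compound 1, and together they hold the highest number of the three. Compound 3 reaches a lower number, so compound 2 sits at the weak end of this small set.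

The next compound, compound 4 `O=c1c(S(=O)(=O)c2ccc(F)cc2F)cc2cnc(Nc3ccc4[nH]ccc4c3)nc2n1C1CCCCC1`, is made from compound 2 by one change: cyclohexyl in place of hydrogen on an aromatic nitrogen. In words, cyclohexyl replaces hydrogen on an aromatic nitrogen, meta to a (2,4-difluorophenyl)sulfonyl group.

Within the data shown here, only one measured step is available for comparison, a 3.0-fold lower number from compound 1 to compound 3 (0.48 log units; beyond the scatter). That step was beyond the scatter but modest, and it lies at a different place on the molecule, on the group attached through a nitrogen. It therefore shows the size of change seen so far in this set, but says nothing direct about the new cyclohexyl. Among the measured compounds shown here, no measured pair changes the group on this ring nitrogen, so any forecast must stay wide.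

A move to a lower number of similar or somewhat greater size is expected, though no change at all remains possible. The expected change is a 3.8-fold lower number from compound 2 to compound 4 (0.57 log units; beyond the scatter). Compound 4 is estimated at 4000 nM, with an expected range from 500 nM to 18000 nM.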

Compound 4, half-maximal inhibitory concentration: 10000 nM
For compound 4 the middle estimate is 2.5-fold (0.40 log units) below the measured one; low and high end bracket the measured number.
By their numbers in this assay, from the lowest: compounds 3, 4, 1 and 2 (each within the scatter of the next, the first and the last beyond it).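

In this assay, cyclohexyl in place of hydrogen on the aromatic nitrogen gives a 1.5-fold lower number from compound 2 to compound 4 (0.18 log units; within the scatter), a step within the scatter, so the two compounds cannot be told apart on this read-out. Among these compounds, this is the first measured step at this position, as the earlier step from compound 1 to compound 3 concerned the group on the other nitrogen. Here, a six-membered carbon ring can replace a lone hydrogen on this ring nitrogen without a change that the assay can resolve, at least with the (2,4-difluorophenyl)sulfonyl group and the indole-bearing amine of compound 2 in place. No measurement at hand offers an explanation for this result.

Going by these compounds, with only hydrogen and cyclohexyl compared directly here, it remains open whether an ethyl group, a longer carbon chain, or a chain ending in an amine or a carboxylic acid would move the number at this nitrogen. On these data alone, it is also open whether cyclohexyl would behave the same way on the sulfonyl and amine groups of compound 3, which gives 5000 nM with its own group on this nitrogen.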